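A Methyl Group Removed from an Aromatic Oxygen

This account rests on a few compounds, and the source may have more. Where it says the series, first, only, none or still open, it means among the compounds named here.

Compound 1, `O=C(Nc1cccc(-n2cc(-c3ccncc3)c(-c3ccc(Cl)c(O)c3)n2)c1)Nc1cccc(C(F)(F)F)c1`: in a functional assay on SNB-19 cells (Homo sapiens) for inhibition, read by sulforhodamine B assay, with a stated time of 48 h (a lower number here means a stronger inhibitor of growth, a higher number a weaker inhibitor of growth), compound 1 gives 1910 nM.
Compound 2, `COc1cc(-c2nn(-c3cccc(NC(=O)Nc4ccc(Cl)c(Cl)c4)c3)cc2-c2ccncc2)ccc1Cl`: in this assay compound 2 gives 1720 nM.

Of the two measured compounds, compound 2 carries the lower number in this assay, but its neighbour compound 1 stands within the usual scatter of it, so the two cannot be told apart and neither counts as the stronger growth inhibitor. Within the data shown here, the two also differ from each other in more than one place, so no single structural step between them can be read off.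

Compound 3, `O=C(Nc1cccc(-n2cc(-c3ccncc3)c(-c3ccc(Cl)c(O)c3)n2)c1)Nc1ccc(Cl)c(Cl)c1`, has not yet been measured in this assay. It is derived from compound 2 by one change: hydrogen in place of methyl on an oxygen on an aromatic ring, so that methoxy becomes hydroxy and 4-chloro-3-methoxyphenyl becomes 4-chloro-3-hydroxyphenyl. Compound 1 already carries this hydroxy group and lands within the scatter of compound 2, so no step beyond the scatter is expected here. Compound 3 is therefore expected to give 1700 nM in this assay, within 800 nM to 3600 nM, an expected change of a 1.0-fold lower number from compound 2 to compound 3 (0.01 log units; within the scatter).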

Compound 3, concentration for 50% growth inhibition: 1460 nM
Beside the measured number, compound 3's estimate is 1.2-fold (0.07 log units) above it, and the stated range covers the measured number.
By their numbers in this assay, from the lowest: compounds 3, 2 and 1 (each within the scatter of the next).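

In this assay, hydrogen in place of methyl on an oxygen on an aromatic ring, turning methoxy into hydroxy, gives a 1.2-fold lower number from compound 2 to compound 3 (0.07 log units; within the scatter), so on the dichlorophenyl urea series the two groups cannot be told apart at this position. Compound 3 also supplies the one-place comparison that the first two compounds lacked: 3,4-dichlorophenyl in place of 3-(trifluoromethyl)phenyl on an amide-type nitrogen, with the 4-chloro-3-hydroxyphenyl group held fixed, gives a 1.3-fold lower number from compound 1 to compound 3 (0.12 log units; within the scatter), so this exchange cannot be read as a change either. Nothing at hand offers an explanation for either result.

The compounds shown carry only hydrogen or methyl on this oxygen, so it stays open whether a larger group there, such as an ethyl or a longer chain, or an amine in place of the hydroxy, would move the number beyond the scatter. From the compounds shown here alone, it also stays open whether the 4-chloro-3-methoxyphenyl group paired with 3-(trifluoromethyl)phenyl would fall in the same narrow band, which would show whether the two exchanges behave independently of each other.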